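Methoxy for Methyl on the Benzyl Arm of Compound 3

The source may hold more compounds than are shown below. What is called first, only, known or untested is meant among the compounds shown, and "the series" means these compounds.

Of the compounds shown here, three built on one shared core have been measured in a functional assay on HT-29 cells (Homo sapiens) for cytotoxicity, read by MTT assay, with a stated time of 24 h; a lower number here means a stronger inhibitor, a higher number a weaker inhibitor. Compound 1 `CN1CCN(CC(=O)Nc2ccc(-c3nc(-c4ccccc4)c(-c4ccccc4)n3C)cc2)CC1` gives 35.5 ug/mL. Compound 2 `CCN1CCN(CC(=O)Nc2ccc(-c3nc(-c4ccccc4)c(-c4ccccc4)n3C)cc2)CC1` gives 75 ug/mL. Compound 3 `Cc1ccc(CN2CCN(CC(=O)Nc3ccc(-c4nc(-c5ccccc5)c(-c5ccccc5)n4C)cc3)CC2)cc1` gives 62 ug/mL. Of these three numbers compound 3 holds the second highest, yet the step of a 1.7-fold higher number from compound 1 to compound 3 (0.24 log units; within the scatter) and the step of a 1.2-fold lower number from compound 2 to compound 3 (0.08 log units; within the scatter) both stay within the scatter, so compound 3 is not set apart from either neighbour. Going by the values given here, only the step of a 2.1-fold higher number from compound 1 to compound 2 (0.32 log units; beyond the scatter) reaches beyond the scatter, and it is modest.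

Compound 4 `COc1ccc(CN2CCN(CC(=O)Nc3ccc(-c4nc(-c5ccccc5)c(-c5ccccc5)n4C)cc3)CC2)cc1` differs from compound 3 in one place: methoxy in place of methyl on an aromatic carbon, on an aromatic carbon of a six-membered aromatic ring of carbon only, para to a large group.

Among the compounds with values here, none of the measured steps bears directly on this change. All three alter the group on the saturated chain carbon bound to the amine nitrogen in the ring, not the aromatic ring of that group. The data therefore offer no direction for the exchange of methyl for methoxy. The expected step is a 1.0-fold lower number from compound 3 to compound 4 (0.01 log units; within the scatter), which is to say none beyond the scatter. In this assay compound 4 is estimated at 60 ug/mL, with a range from 30 ug/mL to 120 ug/mL.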

Compound 4, half-maximal inhibitory concentration: 77.3 ug/mL
For compound 4 the middle estimate is 1.3-fold (0.11 log units) below the measured one; the measured number falls inside the stated range.
By their numbers in this assay, from the lowest: compounds 1, 3, 2 and 4 (each within the scatter of the next, the first and the last beyond it).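

In this assay, the step of a 1.2-fold higher number from compound 3 to compound 4 (0.10 log units; within the scatter) is the only one shown that alters the aromatic ring of the benzyl arm rather than the group on the saturated chain carbon, and it leaves the two compounds unseparated, so 4-methoxybenzyl and 4-methylbenzyl cannot be told apart here. The step of a 1.0-fold higher number from compound 2 to compound 4 (0.01 log units; within the scatter) also stays within the scatter, whereas the step of a 2.2-fold higher number from compound 1 to compound 4 (0.34 log units; beyond the scatter) lies beyond it and is modest, which gives compound 4, like compound 2, a measurable gap from compound 1 that compound 3 does not show, though compounds 2, 3 and 4 remain within the scatter of one another. No measurement among those shown accounts for any of these numbers, so nothing can be said about why methoxy and methyl read alike at this place.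

The compounds shown leave open whether a different group on the same aromatic carbon, such as chlorine, a hydroxyl, an amine or a carboxylic acid, would carry the number beyond the scatter from that of compound 3. They also leave open how a benzyl arm with only hydrogen at this place would read, and so whether methyl and methoxy differ from hydrogen at all.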